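The source may hold more compounds than are shown below. What is called first, only, known or untested is meant among the compounds shown, and "the series" means these compounds.

In an ADME assay on HeLa cells (Homo sapiens) for cytotoxicity, read by MTT assay, with a stated time of 72 h (a lower number here means that less compound is tolerated, a higher number that more compound is tolerated), compound 1 `Nc1sc2c(c1-c1nc3cc(Cl)ccc3s1)CCCC2` gives 107 ug/mL. Compound 2 `Fc1ccc(/C=N/c2sc3c(c2-c2nc4ccccc4s2)CCC3)cc1` gives 372 ug/mL in this assay, and compound 3 `Clc1ccc(/C=N/c2sc3c(c2-c2nc4ccccc4s2)CCC3)cc1` gives 380 ug/mL. Compound 3 therefore sits apart from compound 1 by a gap wider than the scatter, while compound 2 and compound 3 cannot be told apart: the change a 1.0-fold higher number from compound 2 to compound 3 (0.01 log units; within the scatter) lies within the scatter.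

Compound 4 `Fc1ccccc1/C=N/c1sc2c(c1-c1nc3ccccc3s1)CCC2` differs from compound 3 in one place: 2-fluorophenyl in place of 4-chlorophenyl on a carbon with a double bond to nitrogen. Within the data shown here, only one measured step bears on this. Swapping chloro for fluoro on the aromatic carbon, from compound 2 to compound 3, gave no change beyond the scatter. Among the measured compounds shown here, no measured pair speaks to moving the halogen to a different position on that phenyl, so that part of the change has no precedent here.

On this basis compound 4 is expected to behave much like compound 3, with a step of a 1.1-fold lower number from compound 3 to compound 4 (0.04 log units; within the scatter) that stays within the scatter. The estimate for compound 4 in this assay is 350 ug/mL, with a range from 200 ug/mL to 600 ug/mL.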

Compound 4, half-maximal cytotoxic concentration: 355 ug/mL
Beside the measured number, compound 4's estimate is 1.0-fold (0.01 log units) below it, within the range that was stated.
By their numbers in this assay, from the lowest: compound 1; then compounds 4, 2 and 3 (each within the scatter of the next).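

In this assay, among these compounds, the phenyl on the carbon with a double bond to nitrogen tolerates a change in where its halogen sits, which the earlier compounds did not test. Moving the fluorine, with 2-fluorophenyl in place of 4-fluorophenyl, gives a 1.0-fold lower number from compound 2 to compound 4 (0.02 log units; within the scatter) and so stays within the scatter. Changing both the halogen and its place, with 2-fluorophenyl in place of 4-chlorophenyl, gives a 1.1-fold lower number from compound 3 to compound 4 (0.03 log units; within the scatter) and likewise stays within the scatter, so compounds 2, 3 and 4 cannot be told apart. Whether this tolerance extends beyond halogens remains open, since the compounds shown do not tell what an amine or a carboxylic acid on that phenyl would do. No evidence is available to explain why these three numbers stay together.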